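Two Carbamates on One Core, and a Third to Come

The compounds below may be only part of what the source reports. "The series", "measured", "known", "first", "only" and "open" are said of these compounds alone.

Compound 1 `CC(C)COC(=O)Nc1ccc([Se]C#N)cc1` and compound 2 `Cc1ccc(OC(=O)Nc2ccc([Se]C#N)cc2)cc1` share one core and differ only in the group attached through the carbamate oxygen. Each has been tested in a functional assay on CCRF-CEM cells (Homo sapiens) for cytotoxicity, read by MTT assay, with a stated time of 72 h; a higher number here means that more compound is tolerated, a lower number that less compound is tolerated. In this assay compound 1 gives 68700 nM, and compound 2 gives 72000 nM. On these two figures compound 1 sits at the same level as compound 2, the gap between them lying well within the scatter, so the pair cannot be told apart.

Compound 3 `N#C[Se]c1ccc(NC(=O)OCc2ccccc2)cc1` has not yet been measured. It differs from compound 1 in one place: phenyl in place of isopropyl on a saturated chain carbon bound to an oxygen next to a carbonyl group. Within the data shown here, no step between measured compounds covers this change, so there is no direct precedent. Compounds 1 and 2 carry quite different groups at this attachment yet land at the same level, which offers no sign that this part of the molecule shifts the read-out. Compound 3 is therefore expected to stay close to compound 1. The step of a 1.1-fold lower number from compound 1 to compound 3 (0.06 log units; within the scatter) is expected to be no larger than the scatter, in no firm direction. For compound 3 the estimate is 60000 nM, expected to fall between 25000 nM and 150000 nM.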

Compound 3, concentration lethal to 50% of the cells: 73700 nM
Beside the measured number, compound 3's estimate is 1.2-fold (0.09 log units) below it; the measured number falls inside the stated range.
By their numbers in this assay, from the lowest: compounds 1, 2 and 3 (each within the scatter of the next).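

Placing phenyl in place of isopropyl on a saturated chain carbon bound to an oxygen next to a carbonyl group gives, in this assay, a 1.1-fold higher number from compound 1 to compound 3 (0.03 log units; within the scatter), the first direct one-place step at this position. The change is not a small one on paper: the entering group has 6 heavy atoms against 3 for the group that leaves and brings one six-membered aromatic ring where there was no ring, yet the read-out does not separate the two compounds, so in this pair neither the extra heavy atoms nor the ring registers in the cytotoxicity number. No measurement at hand bears on why the read-out holds steady across this change.

Every group shown at this place is built of carbon only and carries no charge, so it remains open whether an amine or a carboxylic acid on this chain would move the number. The compounds shown also all keep the shared core, which leaves open whether changing the core would shift the read-out where this swap did not.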